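Replacing 2-fluorophenyl with 3-methylphenyl: what size of step?

The source may report more compounds than this note shows. Statements on the series, on what has been measured and on what is new or still open speak of the compounds shown alone.

Of the compounds shown here, three that share one core have been measured in a functional assay on HL-60 cells (Homo sapiens) for cytotoxicity, read by WST assay, with a stated time of 48 h; a lower number here means that less compound is needed, a higher number that more compound is needed for the effect. Compound 1 `Clc1ccc(C[C@H]2COC[C@@H]2Cc2ccccc2)cc1Cl` gives 19000 nM, compound 2 `Oc1ccccc1C[C@H]1COC[C@@H]1Cc1ccc(Cl)c(Cl)c1` gives 34000 nM, and compound 3 `Fc1ccccc1C[C@H]1COC[C@@H]1Cc1ccc(Cl)c(Cl)c1` gives 51000 nM. Compound 3 stands at the upper end of these numbers together with compound 2: there is a 1.5-fold higher number from compound 2 to compound 3 (0.18 log units; within the scatter), while the gap to the remaining compound is clearer, with a 2.7-fold higher number from compound 1 to compound 3 (0.43 log units; beyond the scatter).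

Compound 4 `Cc1cccc(C[C@H]2COC[C@@H]2Cc2ccc(Cl)c(Cl)c2)c1` differs from compound 3 in one place: 3-methylphenyl in place of 2-fluorophenyl on a saturated chain carbon bound to a saturated ring carbon. Among the measured compounds shown here, no measured step makes this exact swap, and no measured compound carries a methyl group, so the evidence is indirect. The closest guides are the other changes on the same ring. Beside the fluoro step just given, hydroxy in place of hydrogen came with a 1.8-fold higher number from compound 1 to compound 2 (0.25 log units; within the scatter). All of these steps are small, so in this assay a large change is not expected, and the likeliest outcome is no step beyond the scatter, perhaps with a slight drift to a lower number. The expected step is a 1.5-fold lower number from compound 3 to compound 4 (0.16 log units; within the scatter). Compound 4 is estimated at 35000 nM, with an expected range from 14000 nM to 85000 nM.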

Compound 4, half-maximal effective concentration: 28000 nM
Beside the measured number, compound 4's estimate is 1.3-fold (0.10 log units) above it; low and high end bracket the measured number.
By their numbers in this assay, from the lowest: compounds 1, 4, 2 and 3 (each within the scatter of the next, the first and the last beyond it).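

In this assay the exchange of 2-fluorophenyl for 3-methylphenyl gives a 1.8-fold lower number from compound 3 to compound 4 (0.26 log units; within the scatter) and so does not separate these two groups at this place, on a saturated chain carbon bound to a saturated ring carbon. Among the compounds shown here, the first methyl group in the set also stays close to the other two compounds: a 1.5-fold higher number from compound 1 to compound 4 (0.17 log units; within the scatter) for the added methyl group and a 1.2-fold lower number from compound 2 to compound 4 (0.08 log units; within the scatter) for 3-methylphenyl in place of 2-hydroxyphenyl both leave the numbers within the scatter of each other. Compound 4 therefore stands within the scatter of all three earlier compounds, although compound 1 and compound 3 lie further apart than the scatter, and no measurement here gives a reason for any of these numbers.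

Going by these compounds, whether an amine, a carboxylic acid or a longer chain on this ring would move the number beyond the scatter stays open. Also open, on these data alone, is whether the methyl group would give a similar number on another carbon of the same ring.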